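From (5-hydroxypentyl)amino to dimethylamino

This account rests on a few compounds, and the source may have more. Where it says the series, first, only, none or still open, it means among the compounds named here.

Values in an ADME assay on Vero cells (Chlorocebus sabaeus) for cytotoxicity, with a stated time of 5 days; on this read-out higher numbers stand for weaker inhibition and lower numbers for stronger inhibition:
- Compound 1 `C=CCNc1nc(N)nc2c1ncn2[C@H]1C[C@H](N=[N+]=[N-])[C@@H](CO)O1`: > 100000 nM (a limit)
- Compound 2 `[N-]=[N+]=N[C@H]1C[C@H](n2cnc3c(NCCCCCO)nc(N)nc32)O[C@@H]1CO`: > 100000 nM (a limit)

In this assay compound 2 stands at > 100000 nM, which is a limit and not a number. Compound 1 gives > 100000 nM, also a limit. The whole record so far is the limit of > 100000 nM in this assay, at which 2 of the 2 values shown sit.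

Compound 3 `CN(C)c1nc(N)nc2c1ncn2[C@H]1C[C@H](N=[N+]=[N-])[C@@H](CO)O1` has not yet been measured. The change from compound 2 is dimethylamino in place of (5-hydroxypentyl)amino on an aromatic carbon, next to the ring nitrogen.

Among the compounds with values here, the only measured step bearing on this is a step that the two limits leave unreadable from compound 1 to compound 2. It also changes the substituent on the amino nitrogen at this place, but it gives no size to carry over. With both measured compounds at the limit, nothing points to a step beyond the scatter in this assay, and no direction is expected. The estimate for the step is a number no higher from compound 2 to compound 3 (the limit leaves the size open).

Compound 3 is expected at 100000 nM, with an estimated range from 30000 nM to 100000 nM.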

Compound 3, half-maximal inhibitory concentration: > 100000 nM
Compound 3 was reported as a limit; the forecaster's own chance of this, stated with the estimate: 80%; the middle value sits exactly at the limit.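

In this assay compound 3 gives > 100000 nM, which is a limit and not a number. The steps from compound 1 and compound 2 to compound 3 cannot be read, and the record now stands at one shared limit: the limit of > 100000 nM in this assay, at which 3 of the 3 values shown sit.

The compounds shown leave open whether allylamino, (5-hydroxypentyl)amino and dimethylamino differ at all in this assay.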